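A few compounds are considered here, and "the series" means these few. Any claim that something is new, unique, unknown or untested is made for them only; others in the source may bear on it.

In an ADME assay on RAW264.7 cells (Mus musculus) for cytotoxicity, read by MTT assay, with a stated time of 24 h, in the absence of a further agent (on this read-out higher numbers stand for weaker inhibition and lower numbers for stronger inhibition), compound 1 `COCCCOc1ccc(C(O)C2OC(=O)c3c(OC)cc(OC)cc32)cc1` gives > 40000 nM as a limit and not as a number. Compound 2 `COc1cc(OC)c2c(c1)C(C(O)c1ccc(OCc3ccc(C)cc3)cc1)OC2=O` gives > 40000 nM as a limit too, so its place on the scale is known only as a limit. The step to compound 3 `COc1cc(OC)c2c(c1)C(C(O)c1ccc(OCc3ccc(C#N)cc3)cc1)OC2=O` puts cyano in place of methyl on an aromatic carbon, para to a large group, turning 4-methylbenzyl into 4-cyanobenzyl (cyano in place of methyl on an aromatic carbon). Going by the values given here, only one measured step bears on this change, and it is a step that the two limits leave unreadable from compound 1 to compound 2 with 4-methylphenyl taking the place of 2-methoxyethyl. It offers no size to carry over. What it does show is that both compounds sit at the same limit (the limit of > 40000 nM in this assay, at which 2 of the 2 values shown sit). No step beyond the scatter is therefore expected in this assay and no direction can be favoured. The expected step is a number no higher from compound 2 to compound 3 (the limit leaves the size open) on this estimate. For compound 3 the estimated value is 40000 nM with an expected range of 20000 nM to 80000 nM and a report as a limit is the likeliest outcome.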

Compound 3, half-maximal inhibitory concentration: > 40000 nM
Compound 3: a limit, no number; the forecaster's own chance of this, stated with the estimate: 85%; the middle value sits exactly at the limit.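

In this assay compound 3 adds no readable step: its steps from compound 1 and compound 2 both run between limits, so neither has a size. The compounds shown leave open where on the scale of this assay each one truly lies and whether cyano in place of methyl changes anything there, as all stand at one limit: the limit of > 40000 nM in this assay, at which 3 of the 3 values shown sit.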